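The source may hold more compounds than are shown below. What is called first, only, known or untested is meant among the compounds shown, and "the series" means these compounds.

Working notes on the amide series. The shared core of compound 1 `COc1cc2c(cc1OC)C(CC(N)=O)CC2` carries an unsubstituted amide, and in a functional assay on the whole organism (strain Wistar) for inhibition, with Rattus norvegicus as the target, read by paw edema, with stated times of 60 min and 3 h, at a dose of 100 mg/kg by the oral route (a higher number here means more inhibition at the dose given (going by the name of the read-out), a lower number less inhibition), compound 1 gives 30.4%. Compound 2 `COc1cc2c(cc1OC)C(CC(=O)NC(C)C)CC2` bears an isopropyl group on the amide nitrogen, and in this assay compound 2 gives 30.4%. Compound 3 `CCCCCNC(=O)CC1CCc2cc(OC)c(OC)cc21` bears a pentyl group on the same nitrogen; in this assay compound 3 gives 37.7%, the highest of the three numbers, though each of its gaps to compound 1 and compound 2 stays within the scatter.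

Compound 4 `COc1cc2c(cc1OC)C(CC(=O)NC1CCCCC1)CC2` differs from compound 3 by cyclohexyl in place of pentyl on an amide-type nitrogen. Within the data shown here, the steps that bear on this change are the ones that alter the same amide nitrogen: no change at the digits printed from compound 1 to compound 2 (within the scatter), a number 7.3 percentage points higher from compound 1 to compound 3 (within the scatter) and a number 7.3 percentage points higher from compound 2 to compound 3 (within the scatter). None of them left the scatter, so no move beyond the scatter is expected in this assay for this replacement either, in either direction, and the expected step is a number 1.7 percentage points lower from compound 3 to compound 4 (within the scatter). Compound 4 is therefore estimated at 36%, with a range from 25% to 47%.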

Compound 4, a percentage reported as inhibition, in the whole organism at one dose (the size of the read-out at that dose, not a potency): 49.3%
Estimate against measurement, compound 4: 13.3 percentage points below; the whole stated range lies below it.
By their numbers in this assay, from the lowest: compounds 1, 2 and 3 (each within the scatter of the next); then compound 4.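

In this assay, among these compounds, the change from pentyl to cyclohexyl on the amide-type nitrogen gives a number 11.6 percentage points higher from compound 3 to compound 4 (beyond the scatter) and is the first step at this position to leave the scatter. Cyclohexyl also stands apart from the other two substituents, with a number 18.9 percentage points higher from compound 2 to compound 4 (beyond the scatter) for the change from isopropyl and a number 18.9 percentage points higher from compound 1 to compound 4 (beyond the scatter) for the change from hydrogen, while hydrogen, isopropyl and pentyl stayed within the scatter of one another. Among the compounds shown here, the position therefore does respond to its substituent, and the only ring-bearing group of the four is the one that separates, though this rests on a single example.

A hexyl chain, a cyclopentyl ring or a phenyl ring on the same nitrogen would separate the effect of the ring from that of the carbon count, which the compounds shown cannot do. Nothing measured here bears on why cyclohexyl stands apart.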